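A few compounds are considered here, and "the series" means these few. Any claim that something is new, unique, unknown or untested is made for them only; others in the source may bear on it.

Measured compounds in a functional assay on LNCaP cells (Homo sapiens) for antiproliferative activity, read by MTT assay, with a stated time of 96 h; on this read-out higher numbers stand for weaker inhibition and lower numbers for stronger inhibition:
- compound 1 `CC(CSc1ccc(F)cc1)C(=O)Nc1ccc(C#N)c(C(F)(F)F)c1` gives 8690 nM
- compound 2 `CC(CSc1cccc(OC(F)(F)F)c1)C(=O)Nc1ccc(C#N)c(C(F)(F)F)c1` gives 115000 nM

Of the two compounds measured, compound 1 stands at the lower end: in this assay compound 1 gives 8690 nM, whereas compound 2 gives 115000 nM, a gap that lies well beyond the usual scatter of repeated measurements. The two compounds differ in more than one place, so the gap between them cannot be attributed to a single structural change and is simply noted as what the two values show.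

Compound 3 `CC(CSc1ccc(F)cc1)C(=O)Nc1ccc([N+](=O)[O-])c(C(F)(F)F)c1` has not yet been measured. It differs from compound 1 in a single place: nitro in place of cyano on an aromatic carbon. For the measured compounds named here, no pair of measured compounds shows what this exchange does in this assay, so there is no measured step to rest an expectation on. Both groups are small and uncharged, and nothing in the two measured values points one way or the other. The step from compound 1 to compound 3 is therefore expected to be a 1.1-fold lower number from compound 1 to compound 3 (0.04 log units; within the scatter), that is, no change beyond the scatter. Compound 3 is accordingly estimated to give 8000 nM, with a plausible range from 2500 nM to 25000 nM.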

Compound 3, half-maximal inhibitory concentration: 27200 nM
Compound 3: the middle estimate sits 3.4-fold (0.53 log units) below what was measured; the whole stated range lies below it.
By their numbers in this assay, from the lowest: compound 1; then compound 3; then compound 2.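

In this assay, the aromatic carbon ortho to a trifluoromethyl group and para to a large group proves sensitive to what it carries: putting nitro in place of cyano there gives a modest step beyond the scatter (a 3.1-fold higher number from compound 1 to compound 3 (0.50 log units; beyond the scatter)). Higher numbers stand for weaker inhibition on this read-out, so in this single pair, with the rest of the structure of compound 1 held constant, the cyano group is the better of the two and the nitro group costs some activity, though compound 3 still stands apart from the far higher number of compound 2. No measurement shown here bears on why the exchange has this effect.

The compounds shown leave open whether the exchange would move the number in the same direction and by a similar size in the presence of the trifluoromethoxy group of compound 2 rather than the fluorine of compound 1. They also leave open how an amine, a carboxylic acid or a primary amide on this same aromatic carbon would compare with cyano and nitro.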